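The compounds below may be only part of what the source reports. "The series", "measured", "known", "first", "only" and "open" are said of these compounds alone.

In a functional assay on HT-1080 cells (Homo sapiens) for antiproliferative activity, read by sulforhodamine B assay, with a stated time of 48 h (a higher number here means a weaker inhibitor, a lower number a stronger inhibitor), compound 1 `CC(=O)Nc1ccc(S(=O)(=O)Oc2ccccc2C(C)C)cc1` gives 12000 nM, compound 2 `CCC(=O)Nc1ccc(S(=O)(=O)Oc2ccccc2C(C)C)cc1` gives 2100 nM, and compound 3 `CCCNC(=O)Nc1ccc(S(=O)(=O)Oc2ccccc2C(C)C)cc1` gives 680 nM, the lowest of the three numbers. Both measured steps that end at the lowest number lie beyond the scatter: an 18-fold lower number from compound 1 to compound 3 (1.25 log units; beyond the scatter) and a 3.1-fold lower number from compound 2 to compound 3 (0.49 log units; beyond the scatter). Compound 4 `CC(C)c1ccccc1OS(=O)(=O)c1ccc(NC(=O)NCCCCl)cc1` differs from compound 3 by chloro in place of hydrogen on a saturated chain carbon, three bonds along the chain from an amide-type nitrogen, so that a propyl becomes a 3-chloropropyl. Among the compounds with values here, no measured step touches this chain carbon; all three, including a 5.7-fold lower number from compound 1 to compound 2 (0.76 log units; beyond the scatter), alter the group on the carbonyl carbon. On that basis no step beyond the scatter is expected in this assay, at most a small one in either direction. Compound 4 is therefore estimated at 500 nM, between 200 nM and 1500 nM, which means an expected step of a 1.4-fold lower number from compound 3 to compound 4 (0.13 log units; within the scatter).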

Compound 4, half-maximal inhibitory concentration: 2700 nM
Estimate against measurement, compound 4: 5.4-fold (0.73 log units) below; measured number outside the range, above it.
By their numbers in this assay, from the lowest: compound 3; then compounds 2 and 4 (each within the scatter of the next); then compound 1.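

In this assay, the chain carbon three bonds along the chain from an amide-type nitrogen proves sensitive to substitution, with chloro in place of hydrogen giving a 4.0-fold higher number from compound 3 to compound 4 (0.60 log units; beyond the scatter). With (3-chloropropyl)amino on the carbonyl carbon, the advantage of propylamino over ethyl disappears, at a 1.3-fold higher number from compound 2 to compound 4 (0.11 log units; within the scatter), while part of the advantage over methyl remains, at a 4.4-fold lower number from compound 1 to compound 4 (0.65 log units; beyond the scatter). Nothing available explains this change. The compounds shown leave open whether fluoro, hydroxyl or an amine on this carbon would behave as chloro does. They also leave open whether a longer chain carrying chloro would show the same step.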